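One Substituent Swap, Carried Onto a Second Core

The source may hold more compounds than are shown below. What is called first, only, known or untested is meant among the compounds shown, and "the series" means these compounds.

Compound 1, `COc1cc2c(Oc3ccc(NC(=O)c4cc(-c5ccc(C(F)(F)F)cc5)ccn4)cc3F)ccnc2cc1OCCCN1CCN(C)CC1`, gives 200 nM in a functional assay on HT-29 cells (Homo sapiens) for cytotoxicity, read by MTT assay, with a stated time of 72 h; on this read-out lower numbers stand for stronger inhibition and higher numbers for weaker inhibition.
Compound 2, `COc1ccc(-c2ccnc(C(=O)Nc3ccc(Oc4ccnc5cc(OCCCN6CCN(C)CC6)c(OC)cc45)c(F)c3)c2)cc1`, gives 390 nM in this assay.
Compound 3, `COc1cc2c(Oc3ccc(NC(=O)c4cc(-c5ccc(C(F)(F)F)cc5)ccn4)cc3F)ccnc2cc1OCCCN1CCCC1`, gives 720 nM in this assay.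

Compounds 1 and 2 share one core and differ in a single place: methoxy in place of trifluoromethyl on an aromatic carbon. That change gave a 2.0-fold higher number from compound 1 to compound 2 (0.29 log units; within the scatter). Compound 3 carries a second core. The difference between the two cores is pyrrolidin-1-yl in place of 4-methylpiperazin-1-yl on a saturated chain carbon, three bonds along the chain from an oxygen on an aromatic ring, and that change brought a 3.6-fold higher number from compound 1 to compound 3 (0.56 log units; beyond the scatter). Compound 4, `COc1ccc(-c2ccnc(C(=O)Nc3ccc(Oc4ccnc5cc(OCCCN6CCCC6)c(OC)cc45)c(F)c3)c2)cc1`, has not yet been tested in this assay. It differs from compound 3 by methoxy in place of trifluoromethyl on an aromatic carbon. The place of this change is the same, word for word, as in the step from compound 1 to compound 2, so it counts as the same change, now made on the second core. Within the data shown here, whether a change keeps its size when the core is swapped cannot be read from three numbers; the only guide here is the one measured pair. Because a 2.0-fold higher number from compound 1 to compound 2 (0.29 log units; within the scatter) was seen on the first core, compound 4 is expected to show a step of about a 1.9-fold higher number from compound 3 to compound 4 (0.29 log units; within the scatter). The estimate for compound 4 in this assay is therefore 1400 nM, with a likely range from 600 nM to 3500 nM.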

Compound 4, half-maximal inhibitory concentration: 350 nM
Compound 4: the middle estimate sits 4.0-fold (0.60 log units) above what was measured; the whole stated range lies above it.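

On the second core, the change from trifluoromethyl to methoxy did not repeat what it did on the first, giving a 2.1-fold lower number from compound 3 to compound 4 (0.31 log units; beyond the scatter) in this assay, so in this series its effect cannot simply be carried from one core to the other: the same change on two cores in this assay, a 2.0-fold higher number (0.29 log units; within the scatter) from compound 1 to compound 2 and a 2.1-fold lower number (0.31 log units; beyond the scatter) from compound 3 to compound 4, 4.0-fold (0.60 log units) apart, beyond the scatter of two such steps
The same holds for the other change, pyrrolidin-1-yl in place of 4-methylpiperazin-1-yl, which with methoxy on the aromatic ring gave a 1.1-fold lower number from compound 2 to compound 4 (0.05 log units; within the scatter), so its effect also differs between the two settings: the same change on two cores in this assay, a 3.6-fold higher number (0.56 log units; beyond the scatter) from compound 1 to compound 3 and a 1.1-fold lower number (0.05 log units; within the scatter) from compound 2 to compound 4, 4.0-fold (0.60 log units) apart, beyond the scatter of two such steps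
Both comparisons rest on the same set of compounds, so they are two views of a single finding, that the two changes do not act independently here; they do not show why, and they do not show that any other pair of groups or any other core would behave the same way.

As far as these compounds go, it remains open whether a different group on the aromatic ring, such as chlorine or a nitrile, would also change direction between the two cores. From the compounds shown here alone, it is equally open whether another amine at the end of the chain, such as morpholine, or a longer chain would show the same dependence.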